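A Cycloheptyl Group Swapped for a Dimethylaminobenzyl Group

The source may hold more compounds than are shown below. What is called first, only, known or untested is meant among the compounds shown, and "the series" means these compounds.

Three ureas have been measured in an assay on microsomes from intestine for inhibition of acyl-CoA:cholesterol acyltransferase (Oryctolagus cuniculus); a lower number here means a stronger inhibitor, a higher number a weaker inhibitor. Compound 1 `Cc1cc(C)c(NC(=O)N(Cc2cc(-c3ccccc3)on2)C2CCCCCC2)c(C)c1` gives 61 nM. Compound 2 `Cc1cc(C)c(NC(=O)N(Cc2cccc(-c3csc(C)n3)c2)C2CCCCCC2)c(C)c1` gives 180 nM. Compound 3 `O=C(Nc1c(F)cc(F)cc1F)N(Cc1cccc(-c2cc[nH]n2)c1)C1CCCCCC1` gives 22 nM, the lowest of the three numbers and so the strongest inhibitor of this set; its gap to compound 1 and its gap to compound 2 both lie beyond the usual scatter. Compound 4 `CN(C)c1ccc(CN(Cc2cccc(-c3cc[nH]n3)c2)C(=O)Nc2c(F)cc(F)cc2F)cc1` differs from compound 3 in one place: 4-(dimethylamino)benzyl in place of cycloheptyl on an amide-type nitrogen. For the measured compounds named here, no measured pair shows what this exchange does, so any expectation rests on compound 3 alone. The expected step in this assay is a 3.2-fold higher number from compound 3 to compound 4 (0.50 log units; beyond the scatter), a loss of potency beyond the scatter. Compound 4 is therefore estimated at 70 nM, within a range from 15 nM to 300 nM.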

Compound 4, half-maximal inhibitory concentration: 12 nM
Compound 4: the middle estimate sits 5.8-fold (0.77 log units) above what was measured, outside the stated range (below it).
By their numbers in this assay, from the lowest: compounds 4 and 3 (each within the scatter of the next); then compound 1; then compound 2.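

In this assay, putting 4-(dimethylamino)benzyl in place of cycloheptyl on the amide-type nitrogen gives a 1.8-fold lower number from compound 3 to compound 4 (0.26 log units; within the scatter), so the two compounds cannot be told apart. This position therefore takes a six-membered aromatic ring carrying a nitrogen-containing group as well as a seven-membered ring of carbon only, without a change beyond the scatter. Nothing available explains why the two groups read alike. From the compounds shown here alone, what the dimethylamino group itself contributes remains open, and a plain benzyl group would test that directly. Going by these compounds, whether the same exchange holds on the cores of compound 1 and compound 2 is also open.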